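A few compounds are considered here, and "the series" means these few. Any claim that something is new, unique, unknown or untested is made for them only; others in the source may bear on it.

In a functional assay on HL-60 cells (Homo sapiens) for cytotoxicity, read by WST assay, with a stated time of 48 h (on this read-out lower numbers stand for an effect already at smaller amounts and higher numbers for an effect only at larger amounts of compound), three compounds have been measured:
Compound 1 `Cc1ccccc1C[C@H]1COC[C@@H]1Cc1ccc(Cl)c(Cl)c1` gives 21000 nM
Compound 2 `Oc1ccc(C[C@H]2COC[C@@H]2Cc2ccc(Cl)c(Cl)c2)cc1` gives 31000 nM
Compound 3 `COc1ccc(C[C@H]2COC[C@@H]2Cc2ccc(Cl)c(Cl)c2)cc1` gives 39000 nM

Compound 3 lies within the scatter of both other compounds. Compound 4 `Cc1ccc(C[C@H]2COC[C@@H]2Cc2ccc(Cl)c(Cl)c2)cc1` is still unmeasured and carries methyl in place of methoxy on an aromatic carbon, para to a large group methyl in place of methoxy on an aromatic carbon in its difference from compound 3. For the measured compounds named here, two measured steps bear on this change. Methyl in place of hydrogen on the oxygen gave a 1.3-fold higher number from compound 2 to compound 3 (0.10 log units; within the scatter) and 4-hydroxyphenyl in place of 2-methylphenyl gave a 1.5-fold higher number from compound 1 to compound 2 (0.17 log units; within the scatter) so neither left the scatter. The estimated change is a 1.4-fold lower number from compound 3 to compound 4 (0.14 log units; within the scatter) and no step beyond the scatter is expected in either direction. Compound 4 is expected at 28000 nM with an estimated range from 14000 nM to 55000 nM in this assay as its likely outcome.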

Compound 4, half-maximal effective concentration: 21000 nM
Estimate against measurement, compound 4: 1.3-fold (0.12 log units) above, and the stated range covers the measured number.
By their numbers in this assay, from the lowest: compounds 1, 4, 2 and 3 (each within the scatter of the next).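

With a 1.9-fold lower number from compound 3 to compound 4 (0.27 log units; within the scatter) for methyl in place of methoxy and a 1.5-fold lower number from compound 2 to compound 4 (0.17 log units; within the scatter) for methyl in place of hydroxy, this aromatic carbon has now carried three small groups without any step leaving the scatter. The change from 2-methylphenyl to 4-methylphenyl, with no change at the digits printed from compound 1 to compound 4 (within the scatter) as its step, adds that the place of the methyl on the ring also shows no measurable effect here. As far as these compounds go, what an amine or a carboxylic acid on this aromatic carbon would do remains open. Nothing available explains why these numbers lie so close.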